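A few compounds are considered here, and "the series" means these few. Any claim that something is new, unique, unknown or untested is made for them only; others in the source may bear on it.

Compound 1, `CC(C)(C)c1ccc(NC(=O)NCCCCl)cc1`, gives 28000 nM in a functional assay on HT-29 cells (Homo sapiens) for antiproliferative activity, with a stated time of 48 h; a lower number here means a stronger inhibitor, a higher number a weaker inhibitor.
Compound 2, `CC(C)(C)c1ccc(NC(=O)CCl)cc1`, gives 15000 nM in this assay.
Compound 3, `C=CC(=O)Nc1ccc(I)cc1`, gives 15000 nM in this assay.

Compound 3 stands level with compound 2 at the digits given, and together the two hold the lowest of the three numbers; compound 1 lies furthest away, yet even that distance from compound 3 remains within the scatter, so the three values cannot be ordered with confidence. For the measured compounds named here, the only step between measured compounds is a 1.9-fold lower number from compound 1 to compound 2 (0.27 log units; within the scatter), and it concerns the group on a carbonyl carbon, not the aromatic carbon.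

Compound 4, `C=CC(=O)Nc1ccc(C(C)(C)C)cc1`, is to be measured in this assay. It differs from compound 3 by tert-butyl in place of iodo on an aromatic carbon. Going by the values given here, no measured step changes this position alone: compound 2 also carries tert-butyl on an aromatic carbon, but it differs from compound 3 at the carbonyl as well, so its value bears on the change only indirectly. Given that the single measured step of a 1.9-fold lower number from compound 1 to compound 2 (0.27 log units; within the scatter) stayed within the scatter and that all three numbers sit close together, the expected step of no change at the digits printed from compound 3 to compound 4 (within the scatter) in this assay is none beyond the scatter. For compound 4 the estimate in this assay is 15000 nM, with a range from 5000 nM to 45000 nM.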

Compound 4, half-maximal inhibitory concentration: 24000 nM
Compound 4: middle estimate off by 1.6-fold (0.20 log units), on the low side; the range from low to high includes it.
By their numbers in this assay, from the lowest: compounds 2, 3, 4 and 1 (each within the scatter of the next).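

For the compounds shown here, the new compound gives the first direct reading of this position: in this assay, tert-butyl in place of iodo on an aromatic carbon gives a 1.6-fold higher number from compound 3 to compound 4 (0.20 log units; within the scatter), so exchanging these two groups does not take the value outside the scatter. With tert-butyl held on the aromatic carbon, the group on the carbonyl carbon can also be read in two further steps, and vinyl in place of chloromethyl gives a 1.6-fold higher number from compound 2 to compound 4 (0.20 log units; within the scatter), while vinyl in place of (3-chloropropyl)amino gives a 1.2-fold lower number from compound 1 to compound 4 (0.07 log units; within the scatter). All three steps therefore leave the four compounds unseparated in this read-out, whichever of the two places changes, and nothing available explains this result.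

On these data alone, what an amine or a carboxylic acid on the aromatic carbon would do stays open, as does the effect of a longer chain on the carbonyl carbon. The compounds shown also leave open whether any change at either place can move the number beyond the scatter, and so whether the activity depends on either of these groups at all.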